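Extending an ether chain on a solubility series

The source may hold more compounds than are shown below. What is called first, only, known or untested is meant among the compounds shown, and "the series" means these compounds.

Three compounds share a core carrying two isopropyl groups on a ring, differing in the chain attached through an ester or carbonate. Compound 1 `COCCOCCOCCOCC(=O)Oc1c(C(C)C)cccc1C(C)C` and compound 2 `COCCOCCOCCOCCOCC(=O)Oc1c(C(C)C)cccc1C(C)C` differ by methoxymethyl in place of hydrogen on a saturated chain carbon bound to an oxygen on a saturated carbon. In a physicochemical assay for solubility, in phosphate buffer, at pH 7.4 (on this read-out higher numbers stand for higher solubility and lower numbers for lower solubility), compound 1 gives 990 ug/mL, and compound 2 gives 1580 ug/mL, so the step of a 1.6-fold higher number from compound 1 to compound 2 (0.20 log units; within the scatter) is small. Compound 3 `COCCOCCOCCOC(=O)Oc1c(C(C)C)cccc1C(C)C` gives 190 ug/mL in this assay, the lowest of the three numbers; how its core differs from that of compound 1 is not broken down here.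

Compound 4 `COCCOCCOCCOCCOC(=O)Oc1c(C(C)C)cccc1C(C)C` has not yet been measured. It differs from compound 3 by methoxymethyl in place of hydrogen on a saturated chain carbon bound to an oxygen on a saturated carbon, the same change that was made from compound 1 to compound 2. Since that earlier step, a 1.6-fold higher number from compound 1 to compound 2 (0.20 log units; within the scatter), stayed within the scatter, a step of similar size is expected here, a 1.6-fold higher number from compound 3 to compound 4 (0.20 log units; within the scatter). Compound 4 is therefore estimated to give 300 ug/mL in this assay, most likely between 150 ug/mL and 600 ug/mL.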

Compound 4, solubility: 380 ug/mL
The estimate for compound 4 lay 1.3-fold (0.10 log units) below the measured number, and the stated range covers the measured number.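

In this assay, the same change, methoxymethyl in place of hydrogen on a saturated chain carbon bound to an oxygen on a saturated carbon, gives a 2.0-fold higher number from compound 3 to compound 4 (0.30 log units; within the scatter) on the core of compound 3 and a 1.6-fold higher number from compound 1 to compound 2 (0.20 log units; within the scatter) on the core of compound 1. So on these two cores the change behaves alike, with neither step leaving the usual scatter of repeated measurements, but two pairs cannot show that it truly raises the number or that it would behave the same way on any other core. Nothing offered here speaks to what lies behind either step.

The compounds shown leave open whether a longer chain of the same kind, built up further on either core, would give a step that clears the scatter. They also leave open what an amine or a carboxylic acid in place of the methoxy group would do in this assay on these cores.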